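From Methyl to Phenyl on a Saturated Ring Carbon

The compounds below may be only part of what the source reports. "The series", "measured", "known", "first", "only" and "open" are said of these compounds alone.

Of the compounds shown here, two built on a shared core have been measured in a functional assay on HEK293 cells for positive allosteric modulation of metabotropic glutamate receptor 5 (Homo sapiens), read by calcium flux; on this read-out higher numbers stand for an effect only at larger amounts of compound and lower numbers for an effect already at smaller amounts. Compound 1 `O=C(c1ccc(Cl)cc1)N1CCCn2nc(COc3ccccc3)cc21` gives 390 nM; 389 nM (2 entries) there, and its repeated entries the several entries of compound 1 in this assay, 390 nM; 389 nM (2 entries) agree closely with each other. Going by the values given here, compound 2 `CC(=O)N1c2cc(COc3ccccc3)nn2CCC1C` gives 794 nM in this assay, the only number it has so far; a further entry for compound 2 carries no single number. Among the compounds with values here, compound 1 and compound 2 differ from each other in more than one place, so no single step between them can be read from these values, and they stand here only as two separate results.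

Compound 3 `CC(=O)N1c2cc(COc3ccccc3)nn2CCC1c1ccccc1` has not yet been measured. It differs from compound 2 by phenyl in place of methyl on a saturated ring carbon, a phenyl in place of methyl on a saturated ring carbon. No measured pair among these compounds shows a change of this kind, so there is nothing to tell the size or direction of the step. The step of a 1.1-fold lower number from compound 2 to compound 3 (0.05 log units; within the scatter) is therefore expected to stay within the usual scatter. Compound 3 is expected to give 700 nM in this assay, within a deliberately wide range from 150 nM to 3500 nM.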

Compound 3, half-maximal effective concentration: 5370 nM
Beside the measured number, compound 3's estimate is 7.7-fold (0.88 log units) below it; measured number above the stated range.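

In this assay, phenyl in place of methyl on a saturated ring carbon gives a 6.8-fold higher number from compound 2 to compound 3 (0.83 log units; beyond the scatter). This is the first change in one place among these compounds, and it shows that the position, on the six-membered non-aromatic ring next to the ring nitrogen, is not indifferent to what it carries: with phenyl there, an effect appears only at larger amounts of compound. The step lies beyond the usual scatter, and the one compound with repeated entries shows how closely this read-out can repeat: the several entries of compound 1 in this assay, 390 nM; 389 nM (2 entries)

As far as these compounds go, a single step cannot separate the effect of the larger group from that of its aromatic ring, so it remains open what an ethyl group, a saturated cyclohexyl ring or a small amine would give on this carbon. From the compounds shown here alone, it also remains open whether phenyl at this position would bring a similar change when the acetyl group is replaced by the chlorobenzoyl group carried by compound 1.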